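Working notes: 4-fluorophenyl in place of pyrrolidin-2-yl

A few compounds are considered here, and "the series" means these few. Any claim that something is new, unique, unknown or untested is made for them only; others in the source may bear on it.

Measured in a functional assay on DU-145 cells (Homo sapiens) for antiproliferative activity, read by MTT assay, with a stated time of 24 h; on this read-out higher numbers stand for weaker inhibition and lower numbers for stronger inhibition:
Compound 1 `COc1ccc(-c2noc(-c3ccccc3)n2)cc1OC1CCCC1`: > 1000000 nM (a limit of the assay)
Compound 2 `COc1ccc(-c2noc(C3CCCN3)n2)cc1OC1CCCC1`: 242000 nM

Among the compounds with values here, compound 2 holds the only actual number so far, and the limit of > 1000000 nM in this assay, at which 1 of the 2 values shown sits, is the sole other reading. Compound 3 `COc1ccc(-c2noc(-c3ccc(F)cc3)n2)cc1OC1CCCC1` differs from compound 2 by the change (4-fluorophenyl in place of pyrrolidin-2-yl on an aromatic carbon). Within the data shown here, the one measured step that bears on this is an at least 4.1-fold lower number from compound 1 to compound 2 (0.61 log units; beyond the scatter), which is beyond the scatter and runs the opposite way, with phenyl leaving. A move of similar size toward a higher number is therefore expected in this assay. The expected step is a 3.7-fold higher number from compound 2 to compound 3 (0.57 log units; beyond the scatter). For compound 3 the estimated value is 900000 nM, with an expected range of 350000 nM to 2000000 nM.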

Compound 3, half-maximal inhibitory concentration: 20700 nM
Estimate against measurement, compound 3: 43-fold (1.64 log units) above; the measured number lies below the stated range.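

Phenyl as such does not settle the outcome at this position: fluoro in place of hydrogen gives an at least 48-fold lower number from compound 1 to compound 3 (1.68 log units; beyond the scatter). With 4-fluorophenyl in place of pyrrolidin-2-yl, the result is a 12-fold lower number from compound 2 to compound 3 (1.07 log units; beyond the scatter), so the aromatic group now outdoes the saturated ring, the reverse of the order seen with unsubstituted phenyl. The reading for compound 1 is a limit of the assay, not a number: the limit of > 1000000 nM in this assay, at which 1 of the 3 values shown sits.

Going by these compounds, whether the gain is specific to fluoro stays open; chloro, methoxy or a nitrile in its place would test that. On these data alone, how a piperidine ring would compare with pyrrolidin-2-yl also remains open.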